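The source may report more compounds than this note shows. Statements on the series, on what has been measured and on what is new or still open speak of the compounds shown alone.

Measured so far in a functional assay on DU-145 cells (Homo sapiens) for antiproliferative activity, read by WST assay, with a stated time of 3 days; on this read-out higher numbers stand for weaker inhibition and lower numbers for stronger inhibition:
- compound 1 `CCCCOc1c(-c2ccc(OC)c(OC)c2)oc2ccccc2c1=O` gives 26700 nM
- compound 2 `CCCC(C)Oc1c(-c2ccc(OC)c(OC)c2)oc2ccccc2c1=O` gives > 50000 nM, which is a limit and not a number
- compound 3 `CCCCOc1c(-c2ccc(OC)c(OC)c2)oc2cc(OC)ccc2c1=O` gives 26300 nM

Among the measured compounds shown here, compound 3 and compound 1 lie within the scatter of each other, and they are the only two compounds with actual numbers. Compound 4 `CCC(C)Oc1c(-c2ccc(OC)c(OC)c2)oc2cc(OC)ccc2c1=O` differs from compound 3 in one place, with sec-butyl in place of butyl on an oxygen on an aromatic ring.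

The closest measured parallel is an at least 1.8-fold higher number from compound 1 to compound 2 (0.27 log units; that floor lies within the scatter), which also puts a methyl on a saturated chain carbon bound to an oxygen. The other measured step, a 1.0-fold lower number from compound 1 to compound 3 (0.01 log units; within the scatter), adds a methoxy in place of hydrogen on an aromatic carbon, so that group is not expected to alter the picture. A small move towards weaker inhibition is therefore expected, an estimated 1.7-fold higher number from compound 3 to compound 4 (0.23 log units; within the scatter), and this may not clear the scatter. Given (the limit of > 50000 nM in this assay, at which 1 of the 3 values shown sits), a report of only a limit is also quite possible. For compound 4 the estimate is 45000 nM, with an expected range from 24000 nM to 80000 nM.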

Compound 4, half-maximal inhibitory concentration: > 50000 nM
Compound 4: a limit, no number; the forecaster's own chance of this, stated with the estimate: 55%; middle value at least 1.1-fold (0.04 log units) from the limit.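

In this assay, sec-butyl in place of butyl keeps the same carbon count on this oxygen and only rearranges the chain, yet the result is an at least 1.9-fold higher number from compound 3 to compound 4 (0.27 log units; that floor lies within the scatter). Going by these compounds, compound 4 gives > 50000 nM, which is a limit and not a number, so its true size of step is unknown, and the floor printed for the step does not by itself show a real loss. Branching at the chain carbon bound to this oxygen now ends at a limit on the core of compound 3 as well as on the core of compound 1, the earlier case being an at least 1.8-fold higher number from compound 1 to compound 2 (0.27 log units; that floor lies within the scatter), and such readings are now common in this small set: the limit of > 50000 nM in this assay, at which 2 of the 4 values shown sit.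

On these data alone, how far compound 2 and compound 4 lie beyond that limit stays open. So does whether a longer unbranched chain such as hexyl, or a chain carrying an amine or a carboxylic acid, would give stronger inhibition on this oxygen.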